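The compounds below may be only part of what the source reports. "The series", "measured", "known", "first", "only" and "open" are said of these compounds alone.

Compound 1 `CCc1nc2ccccc2n1CCCCOc1c(Cl)cccc1Cl` and compound 2 `CCc1nc2ccc(C)cc2n1CCCOc1ccc(C)c(Cl)c1` share the same core and were both tested in an ADME assay on Vero cells (Chlorocebus sabaeus) for cytotoxicity, read by luminescence, with a stated time of 2 days; a higher number here means that more compound is tolerated, a lower number that less compound is tolerated. In this assay, going by the values given here, compound 1 gives 13 uM, and compound 2 gives 17 uM; these two numbers lie within the usual scatter of each other, so neither compound stands apart from the other on what has been measured so far, and no step between measured compounds is available to guide a prediction.

Compound 3 `CCc1nc2ccccc2n1CCCCOC` has not yet been measured in this assay. It differs from compound 1 in one place: methyl in place of 2,6-dichlorophenyl on an oxygen on a saturated carbon. The change takes away a ring that carries two chlorine atoms and leaves only a single carbon in its place, so compound 3 is a much smaller molecule than compound 1.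

Among the compounds with values here, with no measured step to lean on, the expectation for this change must stay cautious. Compound 3 is expected to be tolerated somewhat better, with a step of a 2.3-fold higher number from compound 1 to compound 3 (0.36 log units; beyond the scatter) that may reach just beyond the scatter. The number expected for compound 3 in this assay is 30 uM, with a range from 12 uM to 80 uM.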

Compound 3, half-maximal toxic concentration: > 50 uM
Compound 3 ended at the assay's limit (the forecaster's own chance of this, stated with the estimate: 20%); at least 1.6-fold (0.22 log units) between middle value and limit.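

Going by these compounds alone, replacing the 2,6-dichlorophenyl on the oxygen with methyl gives the first measured step for this series in this assay, and that step is an at least 3.8-fold higher number from compound 1 to compound 3 (0.58 log units; beyond the scatter), which shows that what sits at this position can shift the amount of compound the cells tolerate. In this assay compound 3 gives > 50 uM, which is a limit and not a number. The step is therefore only a minimum and its true size stays unknown, since the reading for compound 3 stops at the top of the range that can be read: the limit of > 50 uM in this assay, at which 1 of the 3 values shown sits.

The ring and its two chlorine atoms leave together in this one change, so the step cannot tell whether the chlorine atoms or the ring itself account for the difference, and a plain phenyl on the same oxygen would be needed to separate the two. From the compounds shown here alone, it also remains open how far tolerance depends on size alone, which a longer chain in place of the methyl could test, and whether an amine at this position would keep the reading at the limit.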